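One group changes on the sulfonyl sulfur of compound 3

A few compounds are considered here, and "the series" means these few. Any claim that something is new, unique, unknown or untested is made for them only; others in the source may bear on it.

In an ADME assay on HEK293 cells (Homo sapiens) for cytotoxicity, read by resazurin assay, with a stated time of 48 h (a lower number here means that less compound is tolerated, a higher number that more compound is tolerated), the measured compounds stand as follows
- Compound 1 `O=S(=O)(Nc1ccc(-c2nc3ccccc3o2)cc1)c1cccc(F)c1` gives > 100000 nM (a limit)
- Compound 2 `CS(=O)(=O)Nc1ccc(-c2nc3ccccc3o2)cc1` gives > 100000 nM (a limit)
- Compound 3 `COc1ccc(Cl)cc1S(=O)(=O)Nc1ccc(-c2nc3ccccc3o2)cc1` gives 75000 nM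

Compound 3 alone carries a true number (75000 nM). The other two values are limits, not numbers (the limit of > 100000 nM in this assay, at which 2 of the 3 values shown sit).

Compound 4 `Cc1cccc(S(=O)(=O)Nc2ccc(-c3nc4ccccc4o3)cc2)c1` has 3-methylphenyl in place of 5-chloro-2-methoxyphenyl on a sulfonyl sulfur and is still unmeasured.

Among the measured compounds shown here, two measured steps bear on this change, and both bring in 5-chloro-2-methoxyphenyl: an at least 1.3-fold lower number from compound 1 to compound 3 (0.12 log units; that floor lies within the scatter) (replacing 3-fluorophenyl) and an at least 1.3-fold lower number from compound 2 to compound 3 (0.12 log units; that floor lies within the scatter) (replacing methyl). Each is only a floor, and each floor lies within the usual scatter. Removing that group might therefore raise the number in this assay a little, but no clear change can be counted on.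

The expected step is a 1.3-fold higher number from compound 3 to compound 4 (0.12 log units; within the scatter) and would probably not stand clearly beyond the scatter. For compound 4 the estimate is 100000 nM, with an expected range from 50000 nM to 200000 nM, and the assay may well report only a limit.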

Compound 4, half-maximal cytotoxic concentration: > 100000 nM
Compound 4: no number, only a limit (the forecaster's own chance of this, stated with the estimate: 65%); the middle value sits exactly at the limit.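

Compound 4 joins compound 1 and compound 2 in giving only a limit in this assay, so 3-methylphenyl, 3-fluorophenyl and methyl on a sulfonyl sulfur now share one reading: the limit of > 100000 nM in this assay, at which 3 of the 4 values shown sit.

Putting 3-methylphenyl in place of 5-chloro-2-methoxyphenyl gives an at least 1.3-fold higher number from compound 3 to compound 4 (0.12 log units; that floor lies within the scatter), so even this third comparison with 5-chloro-2-methoxyphenyl shows no clear change. The steps from compound 1 and compound 2 to compound 4 cannot be read, as each joins two limits.

The compounds shown leave open whether the chloro or the methoxy of 5-chloro-2-methoxyphenyl, taken alone, would give a true number in this assay. Also open, on these data alone, is what a phenyl ring carrying an amine or a carboxylic acid would give on the same sulfonyl sulfur.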